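The source may report more compounds than this note shows. Statements on the series, on what has been measured and on what is new or still open speak of the compounds shown alone.

Of the compounds shown here, three that share one core have so far been measured in a functional assay on RAW264.7 cells (Mus musculus) for inhibition, read by Griess assay, with stated times of 1 h and 24 h; a higher number here means a weaker inhibitor, a lower number a stronger inhibitor. Compound 1 `CC(C)CCOc1ccccc1C1CC(=O)c2ccccc2O1` gives 39200 nM, compound 3 `CCCCCOc1ccccc1C1CC(=O)c2ccccc2O1` gives 39200 nM, and compound 2 `CC(C)c1ccc(COc2ccccc2C2CC(=O)c3ccccc3O2)cc1` gives 27100 nM. Compound 2 shows the lowest of the three numbers, yet the step of a 1.4-fold lower number from compound 1 to compound 2 (0.16 log units; within the scatter) and the step of a 1.4-fold higher number from compound 2 to compound 3 (0.16 log units; within the scatter) both lie within the usual scatter of repeated measurements, so none of the three can be told apart on these numbers.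

The next compound, compound 4 `COc1ccccc1C1CC(=O)c2ccccc2O1`, removes the group on the saturated chain carbon bound to the oxygen on the aromatic ring altogether: hydrogen in place of 4-isopropylphenyl on a saturated chain carbon bound to an oxygen on an aromatic ring. The two steps that bear on this place are the ones from compound 1 to compound 2 and from compound 2 to compound 3, where one group was swapped for another of different shape and the number hardly moved. Neither of those steps cut the group back to a bare hydrogen, so the present change goes further than anything measured, and a modest rise in the number would not be surprising. Compound 4 is therefore expected to give about 50000 nM, with a range from 22000 nM to 120000 nM. That expectation corresponds to a 1.8-fold higher number from compound 2 to compound 4 (0.27 log units; within the scatter).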

Compound 4, half-maximal inhibitory concentration: 47300 nM
Compound 4: the middle estimate sits 1.1-fold (0.02 log units) above what was measured; the range from low to high includes it.
By their numbers in this assay, from the lowest: compounds 2, 1, 3 and 4 (each within the scatter of the next).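

In this assay, cutting the group on the saturated chain carbon bound to an oxygen on an aromatic ring back to a bare hydrogen gives a 1.7-fold higher number from compound 2 to compound 4 (0.24 log units; within the scatter) when 4-isopropylphenyl leaves and a 1.2-fold higher number from compound 1 to compound 4 (0.08 log units; within the scatter) when isobutyl leaves and a 1.2-fold higher number from compound 3 to compound 4 (0.08 log units; within the scatter) when butyl leaves. For the compounds shown here, the earlier compounds showed only that one group could be swapped for another at this place, whereas these steps show that the group can be removed altogether, even one of 9 heavy atoms with its six-membered aromatic ring, without a shift that stands clear of the scatter. On these numbers, the four compounds cannot be told apart, so no group tried at this place can be said to help or to harm.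

As far as these compounds go, every group seen here is built from carbon and hydrogen alone, so it remains open whether an amine, a carboxylic acid or a much longer chain at this place, or any change elsewhere on the shared core, would move the number beyond the scatter. No measurement at hand offers an explanation for why these numbers stay so close together.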